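Chain extension at the thioether of a chloromethyl ketone series

This account rests on a few compounds, and the source may have more. Where it says the series, first, only, none or still open, it means among the compounds named here.

Two chloromethyl ketones sharing one core have been measured in a functional assay on NALM-6 cells (Homo sapiens); on this read-out lower numbers stand for stronger inhibition and higher numbers for weaker inhibition. Compound 1 `CSC[C@H](NC(C)=O)C(=O)CCl` gives 30300 nM in this assay. Compound 2 `CCCCCCCSC[C@H](NC(C)=O)C(=O)CCl` gives 4800 nM in this assay. Among the measured compounds shown here, the one step between them, a 6.3-fold lower number from compound 1 to compound 2 (0.80 log units; beyond the scatter), leaves compound 2 with the lowest number of the two, the nearest being compound 1. Compound 3 `CCCCCCCCCCCCSC[C@H](NC(C)=O)C(=O)CCl` takes this direction further: pentyl in place of hydrogen on a saturated chain carbon, seven bonds along the chain from a sulfur. For the measured compounds named here, the only step that bears on it is a 6.3-fold lower number from compound 1 to compound 2 (0.80 log units; beyond the scatter), a modest gain from lengthening the chain bound to the sulfur. A further lengthening is expected to give a smaller gain, or none beyond the scatter, since no second point shows whether the trend continues. The estimate for compound 3 in this assay is 2500 nM, within 800 nM to 8000 nM, meaning an expected step of a 1.9-fold lower number from compound 2 to compound 3 (0.28 log units; within the scatter).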

Compound 3, half-maximal inhibitory concentration: 2000 nM
For compound 3 the middle estimate is 1.3-fold (0.10 log units) above the measured one, and the stated range covers the measured number.
By their numbers in this assay, from the lowest: compound 3; then compound 2; then compound 1.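

In this assay the gain from lengthening the chain on the sulfur does not stop at compound 2: adding pentyl on a saturated chain carbon, seven bonds along the chain from a sulfur, gives a 2.4-fold lower number from compound 2 to compound 3 (0.38 log units; beyond the scatter) and so stays beyond the scatter. The earlier 6.3-fold lower number from compound 1 to compound 2 (0.80 log units; beyond the scatter) was a single point, whereas these two steps now show the same direction across the three compounds, with none going against it. Nothing available here accounts for this trend.

The three compounds leave open whether a still longer chain would lower the number further or whether the trend levels off beyond compound 3. They also leave open how this position would respond to a terminal amine or a carboxylic acid on the chain, or to a phenyl ring in place of its outer carbons.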